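Ethyl in place of hydrogen on the anilino ring

The compounds below may be only part of what the source reports. "The series", "measured", "known", "first", "only" and "open" are said of these compounds alone.

Measured compounds in a functional assay on T-24 cells (Homo sapiens) for antiproliferative activity, read by MTT assay, with a stated time of 48 h; a higher number here means a weaker inhibitor, a lower number a stronger inhibitor:
- compound 1, `Cc1ccc(NC(=O)Nc2cccc(CNc3nccnc3Cl)c2)cc1C`, gives 8930 nM
- compound 2, `O=C(Nc1ccccc1)Nc1cccc(CNc2nccnc2Cl)c1`, gives 19800 nM
- compound 3, `CN(C)c1ccc(NC(=O)Nc2cccc(CNc3nccnc3Cl)c2)cc1`, gives 20200 nM

Compound 2 stands second highest of the three numbers in this assay; compound 3 is nearest, a step of a 1.0-fold higher number from compound 2 to compound 3 (0.01 log units; within the scatter), which is within the scatter, while compound 1 is furthest, the step of a 2.2-fold higher number from compound 1 to compound 2 (0.35 log units; beyond the scatter) lying beyond it. Compound 4, `CCc1ccccc1NC(=O)Nc1cccc(CNc2nccnc2Cl)c1`, differs from compound 2 by ethyl in place of hydrogen on an aromatic carbon.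

Among the measured compounds shown here, two measured steps touch the same anilino ring. The step of a 2.2-fold higher number from compound 1 to compound 2 (0.35 log units; beyond the scatter) shows that removing two methyl groups raises the number modestly; the step of a 1.0-fold higher number from compound 2 to compound 3 (0.01 log units; within the scatter) shows that adding dimethylamino changes nothing beyond the scatter. For the measured compounds named here, no measured compound carries a group ortho to a large group, so the closest guidance is the methyl pair of compound 1. An ethyl group is therefore expected to give at most a modest lowering, possibly none beyond the scatter, in this assay. Compound 4 is estimated at 14000 nM, within 5000 nM to 40000 nM, an expected step of a 1.4-fold lower number from compound 2 to compound 4 (0.15 log units; within the scatter).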

Compound 4, half-maximal inhibitory concentration: 8720 nM
Estimate against measurement, compound 4: 1.6-fold (0.21 log units) above; the measured number falls inside the stated range.
By their numbers in this assay, from the lowest: compounds 4 and 1 (each within the scatter of the next); then compounds 2 and 3 (each within the scatter of the next).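

In this assay there is a step beyond the scatter from one added group on the anilino ring (a 2.3-fold lower number from compound 2 to compound 4 (0.36 log units; beyond the scatter)), with ethyl ortho to a large group, whereas the dimethylamino of the earlier pair gave none (a 1.0-fold higher number from compound 2 to compound 3 (0.01 log units; within the scatter)). One ethyl group at this place matches the 3,4-dimethylphenyl pattern within the scatter (a 1.0-fold lower number from compound 1 to compound 4 (0.01 log units; within the scatter)), and the 2-ethylphenyl and 4-(dimethylamino)phenyl rings stand apart (a 2.3-fold lower number from compound 3 to compound 4 (0.36 log units; beyond the scatter)), so two different substitution patterns on this ring give numbers that cannot be told apart. No measured data on any property of these compounds bear on this step.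

The compounds shown leave open whether the lower number is particular to ethyl or also holds for methyl, propyl or methoxy on the same carbon. They also leave open whether ethyl on another carbon of this ring gives the same step.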